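The compounds below may be only part of what the source reports. "The series", "measured", "known", "first", "only" and "open" are said of these compounds alone.

Values so far in a functional assay on A549 cells (Homo sapiens) for antiproliferative activity, read by MTT assay, with a stated time of 72 h; on this read-out lower numbers stand for stronger inhibition and higher numbers for weaker inhibition:
- compound 1 `O=C(N/N=C/c1ccc([N+](=O)[O-])cc1)Nc1ccc(Oc2ccnc3[nH]ccc23)c(F)c1` gives 20 nM
- compound 2 `COc1ccc(/C=N/NC(=O)Nc2ccc(Oc3ccnc4[nH]ccc34)c(F)c2)c(OC)c1OC` gives 1450 nM
- compound 3 `COc1cc(/C=N/NC(=O)Nc2ccc(Oc3ccnc4[nH]ccc34)c(F)c2)cc(OC)c1OC` gives 34100 nM

Compound 1 stands lowest of the three, and its gaps to compound 2 and compound 3 lie beyond the scatter. Compound 4 `O=C(N/N=C/c1ccc(O)c(Br)c1)Nc1ccc(Oc2ccnc3[nH]ccc23)c(F)c1` keeps the core of compound 1 but changes one group: 3-bromo-4-hydroxyphenyl in place of 4-nitrophenyl on a carbon with a double bond to nitrogen. Among the measured compounds shown here, no measured pair shows this exchange directly. Compound 2 at 1450 nM and compound 3 at 34100 nM both lack the 4-nitrophenyl and both read higher than compound 1, so a rise beyond the scatter, towards weaker inhibition, is expected in this assay for this change. The estimated 15-fold higher number from compound 1 to compound 4 (1.18 log units; beyond the scatter) is accordingly upward. Compound 4 is expected at 300 nM with a range from 30 nM to 3000 nM as the estimate.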

Compound 4, half-maximal inhibitory concentration: 9250 nM
Estimate against measurement, compound 4: 31-fold (1.49 log units) below, outside the stated range (above it).
By their numbers in this assay, from the lowest: compound 1; then compound 2; then compound 4; then compound 3.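

In this assay, among the compounds shown here, the exchange of 4-nitrophenyl for 3-bromo-4-hydroxyphenyl on a carbon with a double bond to nitrogen gives the first direct step at this position: a 460-fold higher number from compound 1 to compound 4 (2.67 log units; beyond the scatter). With the core of compound 1 unchanged, this one group accounts for a large loss of inhibition. Nothing at hand gives a reason for the size of this step. Going by these compounds, the exchange removes the nitro group and adds both a bromine and a hydroxyl, so their separate contributions remain open. A phenyl carrying only the hydroxyl, only the bromine or an amine would help to separate them.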